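Swapping the Cycloheptyl of Compound 1 for 2-Chlorophenyl

The source may hold more compounds than are shown below. What is called first, only, known or untested is meant among the compounds shown, and "the series" means these compounds.

Measured so far:
compound 1 `O=C(O)c1ccccc1-c1ccc(CCc2ncc(CC3CCCCCC3)[nH]2)cc1` — 5.7 nM
compound 2 `CCCCc1cnc(CCc2ccc(-c3ccccc3C(=O)O)cc2)[nH]1` — 93 nM
compound 3 `COc1ccc(Cc2cnc(CCc3ccc(-c4ccccc4C(=O)O)cc3)[nH]2)cc1` — 513 nM

In an in vitro functional assay on cells for agonist activity at Bombesin receptor subtype-3 (Mus musculus), read by luminescence and calcium flux (a lower number here means that less compound is needed, a higher number that more compound is needed for the effect), compound 1 gives the lowest number of the three measured compounds. Compound 2 carries propyl in its place, and the step of a 16-fold higher number from compound 1 to compound 2 (1.21 log units; beyond the scatter) is large. Compound 3 carries 4-methoxyphenyl there, and the step of a 90-fold higher number from compound 1 to compound 3 (1.95 log units; beyond the scatter) is larger still; between the two, a 5.5-fold higher number from compound 2 to compound 3 (0.74 log units; beyond the scatter) is modest.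

Compound 4 `O=C(O)c1ccccc1-c1ccc(CCc2ncc(Cc3ccccc3Cl)[nH]2)cc1` has not yet been measured in this assay. Its difference from compound 1 is 2-chlorophenyl in place of cycloheptyl on a saturated chain carbon bound to an aromatic carbon.

Both measured steps away from compound 1 bear on this change, since each replaces cycloheptyl on the same saturated chain carbon bound to an aromatic carbon. Both moved the number upward and beyond the scatter, and the aromatic replacement in compound 3 moved it furthest. 2-Chlorophenyl is again an aromatic six-membered ring, so an upward step is expected, likely between those seen for compound 2 and compound 3. Compound 4 is therefore expected to sit at about 150 nM, with a range from 30 nM to 800 nM, which amounts to an expected step of a 26-fold higher number from compound 1 to compound 4 (1.42 log units; beyond the scatter).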

Compound 4, half-maximal effective concentration: 22 nM
Estimate against measurement, compound 4: 6.8-fold (0.83 log units) above; measured number below the stated range.
By their numbers in this assay, from the lowest: compound 1; then compound 4; then compound 2; then compound 3.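

In this assay an aromatic ring at this place, on a saturated chain carbon bound to an aromatic carbon, proves compatible with a low number: 2-chlorophenyl in place of cycloheptyl gives a 3.9-fold higher number from compound 1 to compound 4 (0.59 log units; beyond the scatter) as a modest step, far smaller than the step to compound 3 would have suggested. The choice of aromatic group matters a great deal, since replacing 4-methoxyphenyl with 2-chlorophenyl gives a 23-fold lower number from compound 3 to compound 4 (1.37 log units; beyond the scatter) as a large step, while replacing propyl with 2-chlorophenyl gives a 4.2-fold lower number from compound 2 to compound 4 (0.63 log units; beyond the scatter) as a modest one, so that the two aromatic groups fall on opposite sides of propyl and cycloheptyl keeps the lowest number of the four. No supporting measurement accounts for these differences.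

The four compounds leave open whether the gap between compound 3 and compound 4 follows the chlorine, the methoxy group or the place each occupies on the ring, as they change together here. Unsubstituted phenyl, 4-chlorophenyl and 2-methoxyphenyl at this place would separate those possibilities, and cyclohexyl would test how closely the result depends on the seven-membered ring of cycloheptyl.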